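Succinimide propanamides: chloro analogue of compound 3

This account rests on a few compounds, and the source may have more. Where it says the series, first, only, none or still open, it means among the compounds named here.

Measured so far:
compound 1 `CC(C(=O)NCc1cccc(Cl)c1)N1C(=O)CCC1=O` – "not determined" (no result reported)
compound 2 `CC(C(=O)NCc1ccc(C(F)(F)F)cc1)N1C(=O)CCC1=O` – 54.5 mg/kg
compound 3 `CCC(C(=O)NCc1ccccc1)N1C(=O)CCC1=O` – 90.3 mg/kg

The series shares one core, the succinimide-bearing amide seen in compound 1. In a functional assay on the whole organism (strain Albino Swiss CD1) with Mus musculus as the target (a lower number here means that less compound is needed, a higher number that more compound is needed for the effect), compound 1 gives "not determined" (no result reported), so no number is on hand for it. In this assay compound 2 gives 54.5 mg/kg and compound 3 gives 90.3 mg/kg. The two values lie within the usual scatter of each other, so neither can be set apart from the other, and compound 3 is one of only two numbered entries in the set. Going by the values given here, no pair of measured compounds differs in just one place, so no single step of the assay is known.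

Compound 4 `CCC(C(=O)NCc1ccc(Cl)cc1)N1C(=O)CCC1=O` differs from compound 3 by chloro in place of hydrogen on an aromatic carbon. Among the compounds with values here, nothing among the measured compounds isolates the effect of this change; compound 2 carries a different group on a different side chain. The step from compound 3 to compound 4 is therefore expected to stay within the scatter, with no direction favoured: a 1.2-fold lower number from compound 3 to compound 4 (0.08 log units; within the scatter). In this assay compound 4 is estimated at 75 mg/kg, with a range from 35 mg/kg to 150 mg/kg.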

Compound 4, dose for half-maximal effect: 50.8 mg/kg
Beside the measured number, compound 4's estimate is 1.5-fold (0.17 log units) above it; the measured number falls inside the stated range.
By their numbers in this assay, from the lowest: compounds 4, 2 and 3 (each within the scatter of the next).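

The phenyl to 4-chlorophenyl change gives the series its first reading at a single place: in this assay, chloro in place of hydrogen on an aromatic carbon, para to a large group, appears as a 1.8-fold lower number from compound 3 to compound 4 (0.25 log units; within the scatter). The step shows that this position accommodates a chloro, one added heavy atom, without a change beyond the scatter, so compound 3 and compound 4 cannot be set apart on this read-out. No measured data accompany these compounds that could account for the values or for this step.

Still open, going by these compounds, is whether another group at this position, such as fluoro, methoxy, an amine or a carboxylic acid, would give a step beyond the scatter, and whether chloro elsewhere on the aromatic ring would read the same way. Also open, on these data alone, is the effect of a longer chain in place of the alkyl side chain of compound 3, and compound 1 and compound 2 cannot settle either question, as each differs from compound 3 and compound 4 in more than one place.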